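The source may hold more compounds than are shown below. What is called first, only, known or untested is meant among the compounds shown, and "the series" means these compounds.

Compound 2 `O=C(CN1CCN(c2ccccc2)CC1)Nc1nc2ccccc2[nH]1` stands lowest of the three numbers in a functional assay, read by spectrophotometry, with a stated time of 30 min, tested at 25 ug/mL (a lower number here means a weaker effect, a higher number a stronger effect of the compound at the concentration tested), at 11.5%. Compound 1 `CN1CCN(CC(=O)Nc2nc3ccccc3[nH]2)CC1` gives 19.9%, and the step of a number 8.4 percentage points lower from compound 1 to compound 2 (within the scatter) lies within the scatter. Compound 3 `O=C(CN1CCN(c2ccccn2)CC1)Nc1nc2ccccc2[nH]1` gives 40.9%, with a number 29.4 percentage points higher from compound 2 to compound 3 (beyond the scatter) and a number 21 percentage points higher from compound 1 to compound 3 (beyond the scatter). Compound 4 `O=C(CN1CCN(c2ccc([N+](=O)[O-])cc2)CC1)Nc1nc2ccccc2[nH]1` differs from compound 2 by nitro in place of hydrogen on an aromatic carbon. Among the measured compounds shown here, none of the measured steps touches the phenyl itself; all three exchange the whole group on the amine nitrogen in a ring, and the only steps beyond the scatter came with pyridin-2-yl. For the measured compounds named here, no measured step therefore bears directly on this change, and no movement beyond the scatter is expected in this assay. For compound 4 the estimate is 15%, range 4% to 35%. The step of a number 3.5 percentage points higher from compound 2 to compound 4 (within the scatter) is thus expected to stay within the scatter.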

Compound 4, a percentage reported as activity, at one concentration (the size of the read-out at that concentration, not a potency): 33.9%
Beside the measured number, compound 4's estimate is 18.9 percentage points below it; the range from low to high includes it.
By their numbers in this assay, from the lowest: compounds 2 and 1 (each within the scatter of the next); then compounds 4 and 3 (each within the scatter of the next).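

In this assay, among the compounds shown here, a substituent on the phenyl itself moves the number beyond the scatter (a number 22.4 percentage points higher from compound 2 to compound 4 (beyond the scatter)), so this aromatic carbon, para to a large group, responds to change and pyridin-2-yl is not the only group on the amine nitrogen in a ring that gives such a step. The 4-nitrophenyl group stands within the scatter of pyridin-2-yl (a number 7 percentage points lower from compound 3 to compound 4 (within the scatter)) and beyond it from methyl (a number 14 percentage points higher from compound 1 to compound 4 (beyond the scatter)). Nothing shown gives a reason for these steps. Open, from the compounds shown here alone, is whether an amine or a carboxylic acid in place of nitro, para to a large group, would give a comparable step.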